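Cyclohexylamino in place of carboxy: tolerance expectation

This account rests on a few compounds, and the source may have more. Where it says the series, first, only, none or still open, it means among the compounds named here.

Among the compounds with values here, compound 1 `O=c1n(Cc2nc3ccccn3c2CCCCO)c2cnccc2n1C1CC1` is one of two compounds measured in an ADME assay on HEp-2 cells (Homo sapiens) for cytotoxicity, read by CCK-8 assay, with a stated time of 6 days; a lower number here means that less compound is tolerated, a higher number that more compound is tolerated. In this assay compound 1 gives > 100000 nM, a limit of the assay and not a number. Compound 2 `O=C(O)c1c(Cn2c(=O)n(C3CC3)c3ccncc32)nc2cc(Cl)ccn12` is the other. In this assay compound 2 gives > 100000 nM, likewise a limit. Compound 2 thus stands with compound 1 at the limit of > 100000 nM in this assay, at which 2 of the 2 values shown sit. Compound 3 `O=c1n(Cc2nc3cc(Cl)ccn3c2NC2CCCCC2)c2cnccc2n1C1CC1` is not yet measured; it differs from compound 2 by cyclohexylamino in place of carboxy on an aromatic carbon. No measured step is available, so the expected step is a modest move from the shown limit toward a measurable value, an at least 2.0-fold lower number from compound 2 to compound 3 (0.30 log units; that floor lies within the scatter). In this assay compound 3 is estimated at 50000 nM, within 15000 nM to 200000 nM.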

Compound 3, half-maximal cytotoxic concentration: > 100000 nM
Compound 3: no number, only a limit; the forecaster's own chance of this, stated with the estimate: 50%; middle value at least 2.0-fold (0.30 log units) from the limit.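

In this assay compound 3 gives > 100000 nM, a limit and not a number. Within the data shown here, compound 2 also sits at a limit, so no step between compound 2 and compound 3 can be read. The compounds shown leave open whether cyclohexylamino in place of carboxy changes tolerance at all.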